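From cyclopropyl to cyclopentyl on a saturated chain carbon

A few compounds are considered here, and "the series" means these few. Any claim that something is new, unique, unknown or untested is made for them only; others in the source may bear on it.

Values so far in an ADME assay on microsomes from liver (Rattus norvegicus, strain Sprague-Dawley) for metabolic stability, read by LC-MS, using NADPH, with a stated time of 45 min, tested at 3 uM; a higher number here means that the compound lasts longer, a lower number that the compound disappears faster
compound 1 `C1CCC(C(CC2CCCCN2)C2CC2)CC1` gives 0.05 h
compound 2 `C1CCC(C(CC2CCCCN2)C2CCC2)CC1` gives 0.167 h
compound 3 `C1CCC(CC(C2CCCC2)C2CC2)NC1` gives 0.05 h

Compound 3 stands at 0.05 h at the bottom of this small set, level with compound 1, and only compound 2 has a higher number. Compound 4 `C1CCC(CC(C2CCCC2)C2CCCC2)NC1` carries cyclopentyl in place of cyclopropyl on a saturated chain carbon bound to a saturated chain carbon and a saturated ring carbon. Among the measured compounds shown here, the one measured step that bears on this is a 3.3-fold higher number from compound 1 to compound 2 (0.52 log units; beyond the scatter) with cyclobutyl in place of cyclopropyl, on a different core. For the measured compounds named here, no step to cyclopentyl has been measured, so a modest rise of similar size is expected, with wide uncertainty. The expected change is a 3.0-fold higher number from compound 3 to compound 4 (0.48 log units; beyond the scatter) by this estimate. Compound 4 is expected at 0.15 h in this assay, with an estimated range from 0.05 h to 0.45 h for the measurement.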

Compound 4, half-life: 0.233 h
For compound 4 the middle estimate is 1.6-fold (0.19 log units) below the measured one; low and high end bracket the measured number.
By their numbers in this assay, from the lowest: compounds 1 and 3 (each within the scatter of the next); then compounds 2 and 4 (each within the scatter of the next).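

In this assay, replacing cyclopropyl with cyclopentyl at this saturated chain carbon gives a 4.7-fold higher number from compound 3 to compound 4 (0.67 log units; beyond the scatter). A larger ring in this place therefore goes with a longer half-life on a second core as well, and the change now extends beyond cyclobutyl. No measurement shown here gives a reason for this rise. The compounds shown leave open whether a cyclohexyl group at this position would extend the trend, and whether an open chain such as isopropyl would do the same. They also leave open how cyclobutyl would behave on the core of compound 3.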